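Swapping a pyridine attachment on a tolerated compound

A few compounds are considered here, and "the series" means these few. Any claim that something is new, unique, unknown or untested is made for them only; others in the source may bear on it.

Measured so far in an ADME assay on PBMC cells (Homo sapiens) for cytotoxicity (a higher number here means that more compound is tolerated, a lower number that less compound is tolerated), are these compounds:
- Compound 1 (`CC(CCNC(=O)c1c(Cl)cncc1Cl)N1CCC(C(Oc2ccncc2)c2ccc(Br)cc2)CC1`) gives 31200 nM
- Compound 2 (`CCO/N=C(/c1ccc(Br)cc1)C1CCN(C(C)CCNC(=O)c2c(Cl)cncc2Cl)CC1`) gives 33800 nM
- Compound 3 (`CC(CCNC(=O)c1c(Cl)cncc1Cl)N1CCC(C(Oc2ccc(C(F)(F)F)cc2)c2ccc(C(F)(F)F)cc2)CC1`) gives 3100 nM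

Compound 1 and compound 2 stand level, within the usual scatter, while compound 3 gives a lower number, beyond that scatter. Compound 4 (`CC(CCNC(=O)c1c(Cl)cncc1Cl)N1CCC(C(Oc2cccnc2)c2ccc(Br)cc2)CC1`) is still unmeasured. It has pyridin-3-yl in place of pyridin-4-yl on an oxygen on a saturated carbon. Among the compounds with values here, no measured pair shows this kind of change. Starting from compound 1 (31200 nM), no step beyond the scatter is expected in this assay here. The expected size is a 1.0-fold lower number from compound 1 to compound 4 (0.02 log units; within the scatter) and thus within the scatter. Compound 4 is estimated at 30000 nM (range 14000 nM to 60000 nM).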

Compound 4, half-maximal cytotoxic concentration: 32500 nM
The estimate for compound 4 lay 1.1-fold (0.03 log units) below the measured number; measured number inside the range.
By their numbers in this assay, from the lowest: compound 3; then compounds 1, 4 and 2 (each within the scatter of the next).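

In this assay, pyridin-3-yl in place of pyridin-4-yl on an oxygen on a saturated carbon gives a 1.0-fold higher number from compound 1 to compound 4 (0.02 log units; within the scatter), so the two compounds stand level. Within the data shown here, this is the first pair here that differs in one place, and it shows that this read-out does not separate these two pyridine attachments at this position. Going by these compounds, whether pyridin-2-yl, or a phenyl ring carrying an amine or a carboxylic acid, would also stand level at this oxygen remains open. No supporting measurement is available to explain this level result.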